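From fluoro to nitro: notes on compound 4

The source may report more compounds than this note shows. Statements on the series, on what has been measured and on what is new or still open speak of the compounds shown alone.

compound 1 `CCOC(=O)c1nn(-c2ccccc2)c(-c2ccc(F)cc2)c1CNC(C)(C)C`: 365000 nM; 179000 nM (2 entries)
compound 2 `CCOC(=O)c1nn(-c2ccc(Cl)cc2)c(-c2ccccc2)c1CNC(C)(C)C`: > 608000 nM; > 559000 nM (2 entries) (limits)
compound 3 `CC(C)(C)NCc1c(C(=O)O)nn(-c2ccccc2)c1-c1ccc(F)cc1`: > 680000 nM (a limit)

All readings come from a functional assay on NCI-H460 cells (Homo sapiens) for inhibition, read by sulforhodamine B assay, with a stated time of 48 h; a lower number here means a stronger inhibitor of growth, a higher number a weaker inhibitor of growth. Only compound 1 gives numbers. Compound 2 sits at limits of the assay. Compound 3 has no single number and stands only at a limit of the assay, > 680000 nM.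

Compound 4 `CC(C)(C)NCc1c(C(=O)O)nn(-c2ccccc2)c1-c1ccc([N+](=O)[O-])cc1` carries nitro in place of fluoro on an aromatic carbon, para to a large group: nitro in place of fluoro on an aromatic carbon. Going by the values given here, no measured step bears on this change. No step beyond the scatter is expected in this assay, in either direction. The expected step of an at least 1.0-fold lower number from compound 3 to compound 4 (0.03 log units; that floor lies within the scatter) is therefore small. For compound 4 the estimate is 630000 nM, with an expected range of 300000 nM to 750000 nM.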

Compound 4, concentration for 50% growth inhibition: > 634000 nM
Compound 4 gave a limit, no number; the forecaster's own chance of this, stated with the estimate: 75%; middle value at least 1.0-fold (0.00 log units) away from the limit.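

Compound 3 stands only at a limit, > 680000 nM. Compound 4 also stands only at a limit, > 634000 nM, so no step can be read between these two compounds. As far as these compounds go, whether nitro in place of fluoro changes growth inhibition at all remains open.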